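Lengthening the acid chain of compound 3

The source may report more compounds than this note shows. Statements on the series, on what has been measured and on what is new or still open speak of the compounds shown alone.

Compound 3 `O=C(O)CCc1ccc(NCc2ccc(-c3ccccc3)cc2)cc1` gives 251 nM in a functional assay for agonist activity at Free fatty acid receptor 1 (Homo sapiens) (on this read-out higher numbers stand for an effect only at larger amounts of compound and lower numbers for an effect already at smaller amounts), the lowest of the three numbers shown. Compound 2 `O=C(O)CCc1cccc(NCc2cccc(Oc3ccccc3)c2)c1` gives 398 nM in this assay, a gap to compound 3 that lies within the scatter. Among the measured compounds shown here, compound 1 `O=C(O)CCc1ccc(NCc2ccc(Cl)cc2)cc1` gives 1000 nM in this assay, and the step of a 4.0-fold lower number from compound 1 to compound 3 (0.60 log units; beyond the scatter) is the only single-point step among the measured compounds. Compound 4 `O=C(O)CCCc1ccc(NCc2ccc(-c3ccccc3)cc2)cc1` differs from compound 3 by carboxymethyl in place of carboxy on a saturated chain carbon, two bonds along the chain from an aromatic carbon. For the measured compounds named here, no measured step touches this chain, so the step from compound 1 to compound 3 offers no guide, and the expectation rests on the unchanged remainder of compound 3. Compound 4 is therefore expected to give about 500 nM in this assay, between 150 nM and 2000 nM, an estimated step of a 2.0-fold higher number from compound 3 to compound 4 (0.30 log units; within the scatter) that need not exceed the scatter.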

Compound 4, half-maximal effective concentration: 1580 nM
The estimate for compound 4 lay 3.2-fold (0.50 log units) below the measured number, within the range that was stated.
By their numbers in this assay, from the lowest: compounds 3 and 2 (each within the scatter of the next); then compounds 1 and 4 (each within the scatter of the next).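

Lengthening 2-carboxyethyl to 3-carboxypropyl gives a 6.3-fold higher number from compound 3 to compound 4 (0.80 log units; beyond the scatter) in this assay, so the acid chain is a place where one added carbon changes the read-out clearly. Among the compounds shown here, the earlier single-point step concerned only chloro and phenyl on an aromatic carbon, so this is the first reading on the chain itself. No evidence at hand accounts for this result.

Going by these compounds, whether a shorter chain, a methyl group on the chain or a tetrazole in place of the carboxylic acid would give a lower number remains open. So does whether the same lengthening would act alike on compound 1.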